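Replacing the 1H-imidazol-1-yl group of compound 1

A few compounds are considered here, and "the series" means these few. Any claim that something is new, unique, unknown or untested is made for them only; others in the source may bear on it.

Compound 1 `COc1ccccc1OCC1SCCN1C(=O)Cn1ccnc1`: 50 mg/kg
Compound 2 `COC(=O)c1ccc(OCC2SCCN2C(=O)Cn2ccnc2)cc1`: 62 mg/kg
Compound 3 `CCOC(=O)CC(=O)N1CCSC1COc1ccccc1O`: 20 mg/kg

In a functional assay on the whole organism for inhibition, with Cavia porcellus as the target (on this read-out higher numbers stand for an effect only at larger amounts of compound and lower numbers for an effect already at smaller amounts), compound 1 holds the second highest of the three numbers. It lies within the scatter of compound 2, while compound 3 stands beyond the scatter at a lower number. Compound 4 `COc1ccccc1OCC1SCCN1C(=O)CC(=O)N1CCN(C)CC1` keeps the core of compound 1 and differs by (4-methylpiperazin-1-yl)carbonyl in place of 1H-imidazol-1-yl on a saturated chain carbon bound to a carbonyl carbon, with (4-methylpiperazin-1-yl)carbonyl in place of 1H-imidazol-1-yl on a saturated chain carbon bound to a carbonyl carbon. Going by the values given here, no measured pair shows this change alone, so no step beyond the scatter is expected, in either direction. The estimated step is a 1.3-fold lower number from compound 1 to compound 4 (0.10 log units; within the scatter). The range stays wide, given the spread from compound 3 at 20 mg/kg to compound 2 at 62 mg/kg. For compound 4 the expected value is 40 mg/kg, within an estimated range of 15 mg/kg to 100 mg/kg.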

Compound 4, dose for half-maximal effect: 27 mg/kg
Beside the measured number, compound 4's estimate is 1.5-fold (0.17 log units) above it, within the range that was stated.
By their numbers in this assay, from the lowest: compounds 3, 4, 1 and 2 (each within the scatter of the next, the first and the last beyond it).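

In this assay, this change gives a 1.9-fold lower number from compound 1 to compound 4 (0.27 log units; within the scatter), so the two groups cannot be told apart at this position. A six-membered non-aromatic ring bearing a carbonyl thus takes the place of a five-membered aromatic ring on a saturated chain carbon bound to a carbonyl carbon with no step beyond the scatter. Nothing available explains this result. On these data alone, it remains open whether a carboxylic acid or a morpholin-4-ylcarbonyl group in the same place would also stay within the scatter of compound 1, and whether the methyl group on the piperazine matters.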